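From Trifluoromethyl to Chloro on a Shared Core

The compounds below may be only part of what the source reports. "The series", "measured", "known", "first", "only" and "open" are said of these compounds alone.

Compound 1 `COc1ccc(/C=C/C(=O)c2ccc(OC)c3c2OC(C)(C)C=C3)cn1` – > 10000 nM (a limit of the assay)
Compound 2 `COc1ccc(C(=O)/C=C/c2cccc(C(F)(F)F)c2)c2c1C=CC(C)(C)O2` – 9050 nM

Both results come from a functional assay on HT-29 cells (Homo sapiens) for antiproliferative activity, read by MTT assay, with a stated time of 24 h; on this read-out lower numbers stand for stronger inhibition and higher numbers for weaker inhibition. The result for compound 1 is a limit of the assay and not a number. For the measured compounds named here, compound 2 holds the only true number, 9050 nM, so there is no exact value to rank it against.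

Compound 3 `COc1ccc(C(=O)/C=C/c2cccc(Cl)c2)c2c1C=CC(C)(C)O2` has not yet been measured. It carries chloro in place of trifluoromethyl on an aromatic carbon. Going by the values given here, no measured pair of compounds shows what this exchange does, so the expectation starts from compound 2 at 9050 nM, with no direction favoured. The estimated change is a 1.1-fold lower number from compound 2 to compound 3 (0.05 log units; within the scatter), which is expected to stay within the usual scatter of this assay. Compound 3 is expected to give 8000 nM, with an estimated range of 3500 nM to 18000 nM.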

Compound 3, half-maximal inhibitory concentration: > 10000 nM
Compound 3: only a limit was reported; the forecaster's own chance of this, stated with the estimate: 35%; at least 1.2-fold (0.09 log units) between middle value and limit.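

Exchanging trifluoromethyl for chloro on this aromatic carbon gives the only readable step among these compounds: in this assay, the exchange brings an at least 1.1-fold higher number from compound 2 to compound 3 (0.04 log units; that floor lies within the scatter). This floor shows no sign that chloro gives stronger inhibition than trifluoromethyl here, but it leaves open whether the exchange changes the result at all or changes it considerably. The true size of the step stays unknown because the result for compound 3 is a limit of the assay and not a number: the limit of > 10000 nM in this assay, at which 2 of the 3 values shown sit.

The step between compound 1 and compound 3 cannot be read: both results are limits. Going by these compounds, whether another group at this position, such as an amine or a carboxylic acid, would give a number well clear of that limit remains open.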